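Second chloro on two related cores: working notes

The compounds below may be only part of what the source reports. "The series", "measured", "known", "first", "only" and "open" are said of these compounds alone.

Measured in a functional assay on TK-10 cells (Homo sapiens) for cytotoxicity, read by sulforhodamine B assay, with a stated time of 48 h; a higher number here means a weaker inhibitor of growth, a lower number a stronger inhibitor of growth:
compound 1 `ClCc1ccccc1Cn1cnc2c(Cl)nc(Cl)nc21` gives 1450 nM
compound 2 `ClCc1ccccc1Cn1cnc2c(Cl)ncnc21` gives 22900 nM
compound 3 `ClCc1ccccc1Cn1cnc2ncnc(Cl)c21` gives 3460 nM

Compound 1 and compound 2 share a core. The difference between the cores of compound 2 and compound 3 is not broken down here; the two have the same atoms, joined differently. The change from compound 2 to compound 1 is chloro in place of hydrogen on an aromatic carbon, and it gives a 16-fold lower number from compound 2 to compound 1 (1.20 log units; beyond the scatter) in this assay. Compound 4 `ClCc1ccccc1Cn1cnc2nc(Cl)nc(Cl)c21` is not yet measured; the change from compound 3 to compound 4 is chloro in place of hydrogen on an aromatic carbon, the same change made on the other core. Among the measured numbers, compound 3 stands nearest compound 1. Among the measured compounds shown here, the expectation for compound 4 rests on the single measured step of a 16-fold lower number from compound 2 to compound 1 (1.20 log units; beyond the scatter) and is taken somewhat smaller, since one example is a thin basis. For compound 4 the expected step is a 9.9-fold lower number from compound 3 to compound 4 (1.00 log units; beyond the scatter). Compound 4 is estimated at 350 nM, between 100 nM and 1500 nM.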

Compound 4, concentration for 50% growth inhibition: 19500 nM
Compound 4: middle estimate off by 56-fold (1.75 log units), on the low side, outside the stated range (above it).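

In this assay the added chloro gives a 5.6-fold higher number from compound 3 to compound 4 (0.75 log units; beyond the scatter) so the step measured on one core does not carry over to the other, and even its direction differs: the same change on two cores in this assay, a 16-fold lower number (1.20 log units; beyond the scatter) from compound 2 to compound 1 and a 5.6-fold higher number (0.75 log units; beyond the scatter) from compound 3 to compound 4, 89-fold (1.95 log units) apart, beyond the scatter of two such steps.

These two pairs show only that the outcome of this change depends on the core among compound 1, compound 2, compound 3 and compound 4. They give no reason for the reversal and no rule for any further core.

On the aromatic carbon between two ring nitrogen atoms, the compounds shown carry only chloro or hydrogen. As far as these compounds go, whether an amine or a methoxy group at that place would split the same way between the two cores remains open.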